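Trifluoromethoxy for trifluoromethyl: working notes on the series

The compounds below may be only part of what the source reports. "The series", "measured", "known", "first", "only" and "open" are said of these compounds alone.

Measured so far in a functional assay on CWR22R cells (Homo sapiens) for antiproliferative activity, read by propidium iodide staining, with a stated time of 96 h (on this read-out higher numbers stand for weaker inhibition and lower numbers for stronger inhibition), for three compounds:
- compound 1 `CC(O)(CSc1cccc(OC(F)(F)F)c1)C(=O)Nc1ccc(S(F)(F)(F)(F)F)cc1` gives 14000 nM
- compound 2 `CC(O)(CSc1ccccc1OC(F)(F)F)C(=O)Nc1ccc(S(F)(F)(F)(F)F)cc1` gives 15000 nM
- compound 3 `CC(O)(CS(=O)(=O)c1cccc(C(F)(F)F)c1)C(=O)Nc1cccc(S(F)(F)(F)(F)F)c1` gives 24600 nM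

Compound 3 lies within the scatter of both compound 1 and compound 2, so the three values are not separated. Compound 4 `CC(O)(CS(=O)(=O)c1cccc(OC(F)(F)F)c1)C(=O)Nc1cccc(S(F)(F)(F)(F)F)c1` is still unmeasured. Compared with compound 3, it has trifluoromethoxy in place of trifluoromethyl on an aromatic carbon. Going by the values given here, no measured pair isolates this change. Compound 1 and compound 2 both carry trifluoromethoxy but also differ from compound 3 elsewhere, so they offer only indirect guidance. Their values, both within the scatter of compound 3, give no reason to expect a step beyond the scatter in this assay in either direction. The expected 1.2-fold lower number from compound 3 to compound 4 (0.09 log units; within the scatter) is accordingly no real change. For compound 4 the estimated value is 20000 nM with an expected range from 9000 nM to 45000 nM in this series.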

Compound 4, half-maximal inhibitory concentration: 20100 nM
For compound 4 the middle estimate is 1.0-fold (0.00 log units) below the measured one; measured number inside the range.
By their numbers in this assay, from the lowest: compounds 1, 2, 4 and 3 (each within the scatter of the next).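

Going by these compounds alone, compound 3 and compound 4 form the first measured pair that isolates trifluoromethoxy in place of trifluoromethyl, here on an aromatic carbon meta to a large group. In this assay, this exchange gives a 1.2-fold lower number from compound 3 to compound 4 (0.09 log units; within the scatter), so the two compounds are not separated and this position accepts either group without a step beyond the scatter. No evidence in hand bears on this result.

This single pair cannot show whether the same exchange would also stay within the scatter on the core of compound 1 or compound 2. Also open, from the compounds shown here alone, is whether a nitrile, an amine or a carboxylic acid on the same aromatic carbon would give a number beyond the scatter of compound 3, since the two groups compared here do not separate in this assay.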